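A few compounds are considered here, and "the series" means these few. Any claim that something is new, unique, unknown or untested is made for them only; others in the source may bear on it.

Measured compounds in a functional assay on MDA-MB-468 cells (Homo sapiens) for cytotoxicity, read by resazurin assay, with a stated time of 72 h; on this read-out lower numbers stand for stronger inhibition and higher numbers for weaker inhibition:
- compound 1 `S=C(NCc1cccnc1)SCCc1nnc(-c2ccc(Cl)cc2)o1` gives 1980 nM
- compound 2 `S=C(NCc1cccnc1)SCCc1nnc(-c2ccsc2)o1` gives 3260 nM

Compound 2 holds the highest of the two numbers shown; its nearest neighbour is compound 1, and the step of a 1.6-fold higher number from compound 1 to compound 2 (0.22 log units; within the scatter) lies within the scatter, so no order between the two can be read from them. Compound 3 `S=C(NCc1cccnc1)SCCc1nnc(-c2cc3ccccc3s2)o1` has not been measured. It differs from compound 2 by 1-benzothiophen-2-yl in place of thiophen-3-yl on an aromatic carbon. Among the compounds with values here, the only measured step that bears on this position is a 1.6-fold higher number from compound 1 to compound 2 (0.22 log units; within the scatter), where one aromatic group replaced another at the same aromatic carbon without a change beyond the scatter. Within the data shown here, no step shows what the second ring entering here does, and the single exchange seen gives no direction. For compound 3 the expected step in this assay is therefore a 1.2-fold lower number from compound 2 to compound 3 (0.07 log units; within the scatter), nothing beyond the scatter. The estimate for compound 3 is 2800 nM, within 1100 nM to 7000 nM, pending the measurement.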

Compound 3, half-maximal inhibitory concentration: 6770 nM
Compound 3: middle estimate off by 2.4-fold (0.38 log units), on the low side; the measured number falls inside the stated range.
By their numbers in this assay, from the lowest: compounds 1 and 2 (each within the scatter of the next); then compound 3.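

In this assay, the aromatic carbon on the five-membered aromatic ring with 2 nitrogen and 1 oxygen now shows a response beyond the scatter (a 2.1-fold higher number from compound 2 to compound 3 (0.32 log units; beyond the scatter)) when 1-benzothiophen-2-yl enters for thiophen-3-yl, bringing one six-membered aromatic ring of carbon only. The exchange of 4-chlorophenyl for 1-benzothiophen-2-yl points the same way (a 3.4-fold higher number from compound 1 to compound 3 (0.53 log units; beyond the scatter)), so both steps into compound 3 lead to weaker inhibition, though both are modest, while compounds 1 and 2 remain within the scatter of each other. Nothing at hand explains this shift.

The step from compound 2 to compound 3 changes both the ring count and the point of attachment, so thiophen-2-yl would be needed to separate the second ring's contribution from that of the attachment point. From the compounds shown here alone, whether this carbon accepts anything other than an aromatic ring also remains open, for example a carboxylic acid, a morpholine or a short alkyl amine chain.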